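The source may report more compounds than this note shows. Statements on the series, on what has been measured and on what is new or still open speak of the compounds shown alone.

In an ADME assay on HFF cells (Homo sapiens) for cytotoxicity, read by MTT assay, with a stated time of 72 h (on this read-out higher numbers stand for weaker inhibition and lower numbers for stronger inhibition), compound 2 `COc1ccccc1-c1cn(C[C@H](O)[C@H]2OC(=O)C(OCc3ccccc3)=C2OCc2ccccc2)nn1` gives 50 nM, the lowest of the two numbers shown. Compound 3 `O=C1O/C(=C\Cn2cc(-c3cccc(O)c3)nn2)C(OCc2ccccc2)=C1OCc1ccccc1` gives 42600 nM in this assay, far above it. Compound 1 `O=C1O/C(=C\Cn2cc(-c3ccc(Br)cc3)nn2)C(OCc2ccccc2)=C1OCc1ccccc1` is recorded in this assay only as a limit, > 100000 nM. Compound 4 `O=C1O[C@H]([C@@H](O)Cn2ccnn2)C(OCc2ccccc2)=C1OCc1ccccc1` differs from compound 2 by hydrogen in place of 2-methoxyphenyl on an aromatic carbon. For the measured compounds named here, the one measured step at that ring position is an at least 2.3-fold lower number from compound 1 to compound 3 (0.37 log units; beyond the scatter), which compares two compounds built on a core that differs from that of compound 2 and starts from the limit of > 100000 nM in this assay, at which 1 of the 3 values shown sits; it hints only that the group on that ring carbon matters. Going by the values given here, no measured step removes the aromatic ring altogether. Compound 4 is nonetheless expected to inhibit more weakly in this assay, a step of a 100-fold higher number from compound 2 to compound 4 (2.00 log units; beyond the scatter). Compound 4 is estimated at 5000 nM, within a range from 300 nM to 100000 nM.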

Compound 4, half-maximal inhibitory concentration: 610 nM
Beside the measured number, compound 4's estimate is 8.2-fold (0.91 log units) above it; the measured number falls inside the stated range.
By their numbers in this assay, from the lowest: compound 2; then compound 4; then compound 3. At a limit, above all of these: compound 1.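

On the core of compound 2, taking the 2-methoxyphenyl off the aromatic carbon gives a large change with real numbers at both ends, a 12-fold higher number from compound 2 to compound 4 (1.09 log units; beyond the scatter), so the group on that carbon matters on this core too. Even with hydrogen there, compound 4 still gives 610 nM in this assay, so this reading does not depend on the 2-methoxyphenyl. Nothing shown here accounts for the size of this step. Still open, going by these compounds, is how a plain phenyl, a methyl or an amine on that carbon would read, and so whether the ring or its methoxy group carries the step.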